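A few compounds are considered here, and "the series" means these few. Any claim that something is new, unique, unknown or untested is made for them only; others in the source may bear on it.

In a functional assay on A-375 cells (Homo sapiens) for antiproliferative activity, read by CCK-8 assay, with a stated time of 72 h (a higher number here means a weaker inhibitor, a lower number a stronger inhibitor), compound 1 (`Nc1ccccc1NC(=O)c1ccc(CSC(=S)N2CCN(c3ccccc3)CC2)cc1`) gives 3670 nM and compound 2 (`Nc1ccccc1NC(=O)c1ccc(CSC(=S)N2CCc3ccccc32)cc1`) gives 4050 nM, so the two values lie within the scatter of each other. Compound 3 (`Nc1ccccc1NC(=O)c1ccc(CSC(=S)N2CCN(c3ccc(F)cc3)CC2)cc1`) differs from compound 1 by fluoro in place of hydrogen on an aromatic carbon, para to a large group. Among the measured compounds shown here, no measured pair shows a change of this kind, so no shift beyond the scatter is expected in this assay. The expected change is small, a 1.1-fold lower number from compound 1 to compound 3 (0.06 log units; within the scatter). For compound 3 the estimated value is 3200 nM, with an expected range of 1400 nM to 7500 nM.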

Compound 3, half-maximal inhibitory concentration: 9400 nM
Compound 3: middle estimate off by 2.9-fold (0.47 log units), on the low side, and the stated range ends below it.
By their numbers in this assay, from the lowest: compounds 1 and 2 (each within the scatter of the next); then compound 3.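

In this assay, among the compounds shown here, the phenyl of compound 1 does not tolerate every small change: phenyl to 4-fluorophenyl gives a 2.6-fold higher number from compound 1 to compound 3 (0.41 log units; beyond the scatter), the first step. A single fluoro in place of hydrogen, para to a large group, is therefore enough to weaken antiproliferative activity here. Going by these compounds, whether this holds for fluoro alone or for any group at this place stays open, and chloro, methoxy or an amine on the same ring would separate the two. No measurement at hand accounts for the shift.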